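From methoxy to allyloxy: tolerance of compound 4

A few compounds are considered here, and "the series" means these few. Any claim that something is new, unique, unknown or untested is made for them only; others in the source may bear on it.

Measured in an ADME assay on Huh-5-2 cells (Homo sapiens) for cytotoxicity, with a stated time of 3 days; a higher number here means that more compound is tolerated, a lower number that less compound is tolerated:
- compound 1 `CCOC(=O)c1csc([C@H]2[C@@H](COC)C[C@@](CC(C)C)(C(=O)O)N2C(=O)c2ccc(C(C)(C)C)c(OC)c2)n1`: 200000 nM
- compound 2 `COC[C@H]1C[C@@](CC(C)C)(C(=O)O)N(C(=O)c2ccc(C(C)(C)C)c(OC)c2)[C@@H]1c1nccs1`: 200000 nM
- compound 3 `COC[C@H]1C[C@@](CC(C)C)(C(=O)O)N(C(=O)c2ccc(C(C)(C)C)c(OC)c2)[C@H]1COC`: > 120000 nM (a limit)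

Compound 3 has no number, only a limit of > 120000 nM. On these data alone, this is the limit of > 120000 nM in this assay, at which 1 of the 3 values shown sits, so its exact place among the three compounds stays open.

Compound 4 `C=CCOC[C@H]1[C@@H](COC)C[C@@](CC(C)C)(C(=O)O)N1C(=O)c1ccc(C(C)(C)C)c(OC)c1` differs from compound 3 by vinyl in place of hydrogen on a saturated chain carbon bound to an oxygen on a saturated carbon. In other words, methoxymethyl becomes (allyloxy)methyl, with vinyl in place of hydrogen on a saturated chain carbon bound to an oxygen on a saturated carbon.

Going by the values given here, the only measured step that touches compound 3 is a step that the limit leaves unreadable from compound 1 to compound 3. Among the compounds with values here, it involves a different change and gives no size to carry over, so no measured step bears directly on this one. What remains is the general level of the series: compound 1 gives 200000 nM, and compound 2 gives 200000 nM, the same value.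

In this assay, no step beyond the scatter is therefore expected, and no direction can be assigned. The expected step is a step that the limit leaves unreadable from compound 3 to compound 4. Compound 4 may also return only a limit. The estimate for compound 4 is 150000 nM, with an expected range from 60000 nM to 250000 nM.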

Compound 4, half-maximal cytotoxic concentration: > 120000 nM
Compound 4: a limit, no number (the forecaster's own chance of this, stated with the estimate: 45%); the middle value does not contradict the limit.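

In this assay, compound 4 gives only a limit, so no new step can be read from compound 3 or compound 1 to compound 4. Compound 3 and compound 4 both sit at that limit: the limit of > 120000 nM in this assay, at which 2 of the 4 values shown sit.

The compounds shown leave open whether (allyloxy)methyl and methoxymethyl differ in tolerance at all, and where compound 3 and compound 4 stand relative to compound 1 and compound 2.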